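The source may hold more compounds than are shown below. What is called first, only, known or untested is meant among the compounds shown, and "the series" means these compounds.

Working notes on the series. In a functional assay on SGC-7901 cells (Homo sapiens) for antiproliferative activity, read by sulforhodamine B assay, with a stated time of 72 h (on this read-out lower numbers stand for stronger inhibition and higher numbers for weaker inhibition), compound 1 `Fc1cccc(NC(=S)N/N=C/c2ccc3ccccc3n2)c1` gives 79900 nM, the second highest of the three numbers to hand. Compound 3 `NC(=S)N/N=C/c1cc2cccnc2s1` gives 100000 nM in this assay, a figure within the usual scatter of that of compound 1, so no order between the two is read. Compound 2 `CN(C)C(=S)N/N=C/c1nc2ccccc2s1` gives 830 nM in this assay, far lower than compound 1 and well beyond the scatter. Compound 4 `COc1ccccc1NC(=S)N/N=C/c1ccc2ccccc2n1` is not yet measured. It differs from compound 1 in one place: 2-methoxyphenyl in place of 3-fluorophenyl on an amide-type nitrogen. Within the data shown here, no measured pair shows this change, so its step size is unknown; the expected step is small, in no direction beyond the scatter. Compound 4 is therefore expected to give 60000 nM in this assay, within 15000 nM to 200000 nM, an expected step of a 1.3-fold lower number from compound 1 to compound 4 (0.12 log units; within the scatter).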

Compound 4, half-maximal inhibitory concentration: > 100000 nM
Compound 4: no number, only a limit; the forecaster's own chance of this, stated with the estimate: 25%; at least 1.6-fold (0.22 log units) between middle value and limit.
By their numbers in this assay, from the lowest: compound 2; then compounds 1 and 3 (each within the scatter of the next).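

In this assay compound 4 gives > 100000 nM, which is a limit and not a number. Placing 2-methoxyphenyl in place of 3-fluorophenyl on an amide-type nitrogen gives an at least 1.2-fold higher number from compound 1 to compound 4 (0.09 log units; that floor lies within the scatter), the first reading at this position, and the change does not lower the number. The full size of the step stays unread because the reading ends at a limit: the limit of > 100000 nM in this assay, at which 1 of the 4 values shown sits. On these data alone, it remains open whether an alkyl chain or a carboxylic acid-bearing phenyl at this place would shift the number in this assay.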